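Changing the pyridine substituent in a dihydropyridine ester series

A few compounds are considered here, and "the series" means these few. Any claim that something is new, unique, unknown or untested is made for them only; others in the source may bear on it.

Compound 1: `CC1=NC(C)=C([N+](=O)[O-])C(c2cccc(C)n2)/C1=C(/O)OC(C)C` — 25100 nM
Compound 2: `CO/C(O)=C1/C(C)=NC(C)=C([N+](=O)[O-])C1c1cccc(C)n1` — 2290 nM
Compound 3: `CC1=NC(C)=C([N+](=O)[O-])C(c2cccc(C)n2)/C1=C(/O)OCCc1ccccc1` — 9980 nM

These three compounds share one core and differ only in the group on the ester oxygen. In a functional assay (muscle tissue) with Cavia porcellus as the target (on this read-out lower numbers stand for stronger inhibition and higher numbers for weaker inhibition), compound 3 gives 9980 nM, the second highest of the three numbers, with a 2.5-fold lower number from compound 1 to compound 3 (0.40 log units; beyond the scatter) and a 4.4-fold higher number from compound 2 to compound 3 (0.64 log units; beyond the scatter) framing it. Compound 4 is `CC1=NC(C)=C([N+](=O)[O-])C(c2cccc([N+](=O)[O-])n2)/C1=C(/O)OCCc1ccccc1`; the change is nitro in place of methyl on an aromatic carbon. Among the measured compounds shown here, none of the measured steps touches this ring: the known steps, an 11-fold lower number from compound 1 to compound 2 (1.04 log units; beyond the scatter) and the two above, all concern the ester oxygen, so they give no guidance on size or direction here. For the measured compounds named here, with no comparable step, the expectation for compound 4 is a 1.0-fold higher number from compound 3 to compound 4 (0.00 log units; within the scatter), a change within the scatter, so compound 4 is estimated at 10000 nM, ranging from 2500 nM to 40000 nM.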

Compound 4, half-maximal inhibitory concentration: 4740 nM
Beside the measured number, compound 4's estimate is 2.1-fold (0.32 log units) above it; low and high end bracket the measured number.
By their numbers in this assay, from the lowest: compound 2; then compound 4; then compound 3; then compound 1.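

Among the compounds shown here, the group on the ring, not only the one on the ester oxygen, can shift the result in this assay: replacing methyl with nitro, next to the ring nitrogen, gives a 2.1-fold lower number from compound 3 to compound 4 (0.32 log units; beyond the scatter). The data here offer no measured explanation for this shift.

As far as these compounds go, only the phenethyl ester carries the nitro group here, so it remains open whether the same change would shift the number with the methyl or isopropyl ester. Also open, from the compounds shown here alone, is how an amine, a chlorine or a methoxy group would compare at this ring position.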